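Replacing the glycolamide with a methanesulfonamide on the chain

The source may report more compounds than this note shows. Statements on the series, on what has been measured and on what is new or still open speak of the compounds shown alone.

Measured so far:
compound 1 `N=C(N)NC(=O)C[C@@H]1CCCc2cc(S(=O)(=O)c3cccc(F)c3)ccc21` — 0.631 nM
compound 2 `O=C(CO)NC[C@@H]1CCCc2cc(S(=O)(=O)c3cccc(F)c3)ccc21` — 0.1 nM

In an assay on isolated protein for displacement of a labelled ligand from 5-hydroxytryptamine receptor 6 (Homo sapiens) (a lower number here means a stronger inhibitor, a higher number a weaker inhibitor), compound 2 holds the lowest of the two numbers, with compound 1 the nearest. Within the data shown here, the only step seen so far, a 6.3-fold lower number from compound 1 to compound 2 (0.80 log units; beyond the scatter), exchanges the group on the same chain carbon and is modest in size. Compound 3 `CS(=O)(=O)NC[C@@H]1CCCc2cc(S(=O)(=O)c3cccc(F)c3)ccc21` differs from compound 2 by methylsulfonyl in place of (hydroxymethyl)carbonyl on an amine nitrogen. The measured step speaks only loosely to this change, so a step of no more than modest size in either direction is expected. Compound 3 is expected to give 0.25 nM, within 0.06 nM to 1 nM. The expected step is a 2.5-fold higher number from compound 2 to compound 3 (0.40 log units; beyond the scatter).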

Compound 3, inhibition constant: 0.2 nM
Compound 3: middle estimate off by 1.3-fold (0.10 log units), on the high side; measured number inside the range.
By their numbers in this assay, from the lowest: compounds 2 and 3 (each within the scatter of the next); then compound 1.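

In this assay, methylsulfonyl in place of (hydroxymethyl)carbonyl on the amine nitrogen gives a 2.0-fold higher number from compound 2 to compound 3 (0.30 log units; within the scatter), so a carbonyl on this nitrogen is not required for a number in this range. Compound 3 also stays clear of compound 1, with a 3.2-fold lower number from compound 1 to compound 3 (0.50 log units; beyond the scatter), so two different groups on this chain now read lower than the group in compound 1. Nothing available explains these numbers.

From the compounds shown here alone, whether a free amine or a longer chain bearing the methanesulfonamido group would hold this range remains open. The shared core is constant throughout, so these steps say nothing about changes there.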